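Isopropyl to isobutyl on the benzamide oxygen of compound 2

A few compounds are considered here, and "the series" means these few. Any claim that something is new, unique, unknown or untested is made for them only; others in the source may bear on it.

Compound 1 `CCOc1ccc(-c2c(NC(=O)c3ccc(OCC(C)C)cc3)c(C(=O)O)nn2-c2ccc(Oc3ccccc3)cc2)cc1` gives 1040 nM in an assay for displacement of a labelled ligand from Apoptosis regulator Bcl-2 (Homo sapiens), read by fluorescence polarization, with a stated time of 30 min; a higher number here means a weaker inhibitor, a lower number a stronger inhibitor.
Compound 2 `CC(C)Oc1ccc(C(=O)Nc2c(C(=O)O)nn(-c3ccc(Oc4ccccc4)cc3)c2-c2ccc(OC(C)C)cc2)cc1` gives 140 nM in this assay.

Compound 2 holds the lower of the two numbers, and compound 1 stands a good way above it, beyond the scatter; the two compounds differ in more than one place, so nothing is drawn from that gap about any single change. Compound 3 `CC(C)COc1ccc(C(=O)Nc2c(C(=O)O)nn(-c3ccc(Oc4ccccc4)cc3)c2-c2ccc(OC(C)C)cc2)cc1` is not yet measured. It differs from compound 2 as isobutyl in place of isopropyl on an oxygen on an aromatic ring. Among the compounds with values here, no measured pair shows this change on its own. The isobutoxy group of compound 3 is also carried by compound 1, yet compound 1 differs from compound 3 elsewhere too, so no direction is settled. Compound 3 is expected to sit close to compound 2, with the step of a 1.6-fold higher number from compound 2 to compound 3 (0.20 log units; within the scatter) estimated to be small, perhaps a little toward the weaker side, and within the scatter. Compound 3 is estimated at 220 nM, within the range 80 nM to 600 nM.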

Compound 3, inhibition constant: 1400 nM
For compound 3 the middle estimate is 6.4-fold (0.80 log units) below the measured one; the measured number lies above the stated range.
By their numbers in this assay, from the lowest: compound 2; then compounds 1 and 3 (each within the scatter of the next).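

One added carbon at this oxygen matters: isobutyl in place of isopropyl gives a 10-fold higher number from compound 2 to compound 3 (1.00 log units; beyond the scatter) in this assay, the first single change here shown to move the number beyond the scatter. The other step, methyl in place of hydrogen on a saturated chain carbon bound to an oxygen on an aromatic ring and a saturated chain carbon, gives a 1.3-fold higher number from compound 1 to compound 3 (0.13 log units; within the scatter), within the scatter, so with isobutyl in place that change has no readable effect. Nothing available explains the sensitivity to the isobutyl group.

Going by these compounds, it remains open whether that second change would also be silent with isopropyl on the first oxygen. On these data alone, it is equally open how a methyl group, a straight propyl chain or a longer chain would read on this oxygen.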